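Removing one fluoro from the sulfonyl ring of compound 1

The source may report more compounds than this note shows. Statements on the series, on what has been measured and on what is new or still open speak of the compounds shown alone.

Compound 1 `O=C(NO)c1ccc(CN(Cc2ccc(F)cc2)S(=O)(=O)c2c(F)c(F)c(F)c(F)c2F)cc1` gives 367 nM in an assay on isolated protein for inhibition of histone deacetylase 8 (Homo sapiens), read by mobility shift assay (on this read-out lower numbers stand for stronger inhibition and higher numbers for weaker inhibition), the highest of the two plain numbers shown. Compound 3 `Cc1ccc(CN(Cc2ccc(C(=O)NO)cc2)S(=O)(=O)c2c(F)c(F)c(F)c(F)c2F)cc1` gives 101 nM there, a change of a 3.6-fold lower number from compound 1 to compound 3 (0.56 log units; beyond the scatter). Compound 2 `CN(C)c1ccc(CN(Cc2ccc(C(=O)NO)cc2)S(=O)(=O)c2c(F)c(F)c(F)c(F)c2F)cc1` reaches only the limit > 1000 nM in this assay. Compound 4 `O=C(NO)c1ccc(CN(Cc2ccc(F)cc2)S(=O)(=O)c2cc(F)c(F)c(F)c2F)cc1` differs from compound 1 by hydrogen in place of fluoro on an aromatic carbon. Within the data shown here, every measured step here — an at least 2.7-fold higher number from compound 1 to compound 2 (0.43 log units; beyond the scatter), a 3.6-fold lower number from compound 1 to compound 3 (0.56 log units; beyond the scatter) and an at least 9.9-fold lower number from compound 2 to compound 3 (0.99 log units; beyond the scatter) — alters the other benzyl ring, not the pentafluorophenyl group, so no step directly bears on this change. Compound 4 is therefore expected to stay close to compound 1, with a step of a 1.1-fold higher number from compound 1 to compound 4 (0.04 log units; within the scatter) that should fall within the scatter. The estimate for compound 4 is 400 nM, ranging from 150 nM to 1000 nM.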

Compound 4, half-maximal inhibitory concentration: 860 nM
Estimate against measurement, compound 4: 2.2-fold (0.33 log units) below; measured number inside the range.
By their numbers in this assay, from the lowest: compound 3; then compound 1; then compound 4. At a limit, above all of these: compound 2.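

Among these compounds, the step of a 2.3-fold higher number from compound 1 to compound 4 (0.37 log units; beyond the scatter) in this assay shows that the 2,3,4,5,6-pentafluorophenyl group, untouched by the earlier steps, also matters for the number. At this position on the ring, fluoro goes with the lower number and hydrogen with the higher one, a single-atom swap that changes the result by more than the scatter. Nothing measured here accounts for this step.

From the compounds shown here alone, it remains open how a methyl group, a methoxy group or an amine at this position would read. Going by these compounds, whether removing any other fluoro from the ring gives a similar step also remains open.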